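Amides on a shared naphthol core: from cyclobutyl to phenyl

The compounds below may be only part of what the source reports. "The series", "measured", "known", "first", "only" and "open" are said of these compounds alone.

Measured compounds:
compound 1, `CC(=O)Nc1c(C(O)(C(F)(F)F)C(F)(F)F)ccc2ccccc12`, 18 nM
compound 2, `CC(C)CCC(=O)Nc1c(C(O)(C(F)(F)F)C(F)(F)F)ccc2ccccc12`, 49 nM
compound 3, `O=C(Nc1c(C(O)(C(F)(F)F)C(F)(F)F)ccc2ccccc12)C1CCC1`, 45 nM

All three share one core and differ only in the group on the amide carbonyl carbon. In an assay on LtK cells with ATP-sensitive inward rectifier potassium channel 11 (Homo sapiens) as the target (a higher number here means that more compound is needed for the effect, a lower number that less compound is needed), compound 1 gives the lowest number of the three. Compound 2 and compound 3 sit close together: the step of a 1.1-fold lower number from compound 2 to compound 3 (0.04 log units; within the scatter) is within the scatter, so nothing separates them. Against compound 1 both stand higher, by a 2.7-fold higher number from compound 1 to compound 2 (0.43 log units; beyond the scatter) and by a 2.5-fold higher number from compound 1 to compound 3 (0.40 log units; beyond the scatter). Compound 3 thus stands second of three, within the scatter of compound 2 and beyond it from compound 1.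

Compound 4, `O=C(Nc1c(C(O)(C(F)(F)F)C(F)(F)F)ccc2ccccc12)c1ccccc1`, is not yet measured. It differs from compound 3 by phenyl in place of cyclobutyl on a carbonyl carbon. Among the measured compounds shown here, the steps that bear on it are those that enlarge the group on the carbonyl carbon: from methyl to cyclobutyl or to isopentyl the number rose modestly, and between cyclobutyl and isopentyl it did not move beyond the scatter. No aromatic group on this carbonyl has been measured, so the direction is uncertain. Compound 4 is therefore expected to stay near compound 3, with at most a small rise, a 1.3-fold higher number from compound 3 to compound 4 (0.12 log units; within the scatter). The estimate for compound 4 in this assay is 60 nM, within 20 nM to 180 nM.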

Compound 4, half-maximal effective concentration: 44 nM
For compound 4 the middle estimate is 1.4-fold (0.13 log units) above the measured one; low and high end bracket the measured number.
By their numbers in this assay, from the lowest: compound 1; then compounds 4, 3 and 2 (each within the scatter of the next).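

Putting phenyl in place of cyclobutyl on the carbonyl carbon exchanges a four-membered non-aromatic ring for a six-membered aromatic one, yet this assay does not separate the two compounds: a 1.0-fold lower number from compound 3 to compound 4 (0.01 log units; within the scatter). Among the compounds shown here, the phenyl compound is equally inseparable from the open-chain isopentyl compound, with a 1.1-fold lower number from compound 2 to compound 4 (0.05 log units; within the scatter), so at this position the isopentyl chain, the cyclobutyl ring and the phenyl ring cannot be told apart, and an aromatic ring brings no distinct result in these compounds, while the methyl of compound 1 remains the only group that stands apart, with a 2.4-fold higher number from compound 1 to compound 4 (0.39 log units; beyond the scatter), in the same direction as the steps to the other two larger groups. Nothing in the information available accounts for this flat result among the three larger groups.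

The compounds shown leave open whether a phenyl ring carrying a chlorine or a methoxy group, a pyridine ring, or an amine on the carbonyl carbon would move the number away from this level. They also leave open where the rise sets in between methyl and the larger groups, which an ethyl or a cyclopropyl group on the carbonyl carbon could show.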